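The source may hold more compounds than are shown below. What is called first, only, known or untested is meant among the compounds shown, and "the series" means these compounds.

Measured so far:
- compound 1, `Nc1nc(Cl)c2ncn(Cc3ccc(CCl)cc3)c2n1`: 21900 nM
- compound 2, `ClCc1ccccc1Cn1cnc2nc(Cl)nc(Cl)c21`: 2510 nM

In a functional assay on A498 cells (Homo sapiens) for cytotoxicity, read by sulforhodamine B assay, with a stated time of 48 h (on this read-out lower numbers stand for stronger inhibition of growth and higher numbers for weaker inhibition of growth), compound 2 gives 2510 nM, the lower of the two numbers; compound 1, whose number is 21900 nM, sits higher by a gap beyond the scatter. The two differ in more than one place, so nothing can be read from them about any single change.

Compound 3, `ClCc1ccccc1Cn1cnc2ncnc(Cl)c21`, is the unmeasured follow-up to compound 2. It differs from compound 2 as follows: hydrogen in place of chloro on an aromatic carbon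

Among the compounds with values here, no measured pair here carries this same change, so the expected size of the step rests on general experience only. The chloro that leaves sits on the core itself, between two ring nitrogen atoms, and its removal is expected to cost some growth inhibition in this assay, with a step of roughly a 2.0-fold higher number from compound 2 to compound 3 (0.30 log units; within the scatter), though a step within the scatter cannot be ruled out. Compound 3 is therefore estimated at 5000 nM, within the range 1500 nM to 20000 nM.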

Compound 3, concentration for 50% growth inhibition: 18600 nM
Estimate against measurement, compound 3: 3.7-fold (0.57 log units) below; the range from low to high includes it.
By their numbers in this assay, from the lowest: compound 2; then compounds 3 and 1 (each within the scatter of the next).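

Within the data shown here, compound 2 and compound 3 are the first pair that differ in one place, so the chloro between two ring nitrogen atoms can now be judged on its own. Hydrogen in place of chloro on this aromatic carbon gives a 7.4-fold higher number from compound 2 to compound 3 (0.87 log units; beyond the scatter) in this assay and, with the step beyond the scatter, this position is shown to matter for growth inhibition, with chloro giving the lower number of the two groups seen there. Nothing measured here bears on what lies behind the step.

On these data alone, whether a methoxy group or a bromo group at this position would keep the growth inhibition of the chloro remains open. As far as these compounds go, the role of the other chloro on the core, meta to this position, is also open, and compound 1 differs from the others in more than one place, so its steps cannot be read.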